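Mirror Image of a Weakly Cytotoxic Stereoisomer

The compounds below may be only part of what the source reports. "The series", "measured", "known", "first", "only" and "open" are said of these compounds alone.

Compound 1 `CCOC(=O)[C@@]1(C(=O)Nc2ccccc2)C[C@@H]1c1cc(OC)c(OC)c(OC)c1` has been tested in a functional assay on QGY cells (Homo sapiens) for cytotoxicity, read by MTT assay, with a stated time of 48 h (a higher number here means a weaker inhibitor, a lower number a stronger inhibitor), with its configuration defined. Compound 1 gives > 100000 nM, which is a limit of the assay and not a number. Beside it stands compound 2 `CCOC(=O)C1(C(=O)Nc2ccccc2)CC1c1cc(OC)c(OC)c(OC)c1`, and what separates the pair is the fact that one of compounds 1 and 2 is drawn with a defined configuration and the other without, at the place where they differ. Compound 2 gives 59300 nM; > 100000 nM (2 entries).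

Still unmeasured is compound 3 `CCOC(=O)[C@]1(C(=O)Nc2ccccc2)C[C@H]1c1cc(OC)c(OC)c(OC)c1`, which relates to compound 1 as follows: the two compounds have the same atoms and bonds and differ only in configuration as drawn: 2 of 2 stereo elements differ (all stereocentres are inverted: mirror images); a stereocentre at a saturated ring carbon is drawn S in compound 1 and R in compound 3; a stereocentre at a saturated ring carbon is drawn R in compound 1 and S in compound 3. The two compounds have the same atoms and bonds and differ only in configuration as drawn, as mirror images. No measured step between any of these compounds shows what such an inversion does in this assay. The expectation therefore rests on compound 2 at 59300 nM; > 100000 nM (2 entries), whose one number still marks a weak inhibitor. An estimated at least 1.1-fold lower number from compound 1 to compound 3 (0.07 log units; that floor lies within the scatter) is expected, which would be no step beyond the scatter. Compound 3 is estimated at 85000 nM, with an expected range from 35000 nM to 200000 nM.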

Compound 3, half-maximal inhibitory concentration: > 100000 nM
Compound 3 ended at the assay's limit; the forecaster's own chance of this, stated with the estimate: 60%; middle value at least 1.1-fold (0.07 log units) away from the limit.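

Compound 3 gives > 100000 nM, a limit of the assay and not a number. Compound 1 gives > 100000 nM, likewise a limit. The step between compound 1 and compound 3 therefore cannot be read, as both values stop at the same limit: the limit of > 100000 nM in this assay, at which 2 of the 3 values shown sit.

From the compounds shown here alone, whether these two mirror images differ at all in cytotoxicity remains open.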